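The source may report more compounds than this note shows. Statements on the series, on what has been measured and on what is new or still open speak of the compounds shown alone.

Of the compounds shown here, two with a shared core have been measured in a functional assay on DU-145 cells (Homo sapiens) for cytotoxicity, read by MTT assay, with a stated time of 72 h; on this read-out lower numbers stand for an effect already at smaller amounts and higher numbers for an effect only at larger amounts of compound. Compound 1 `CCc1cccc2c(OC)c(-c3occ(C)c3C(=O)OC)ccc12` gives 2.2 ug/mL. Compound 2 `CCc1cccc2c(OC)c(-c3occ(C)c3CO)ccc12` gives 7.2 ug/mL, the higher of the two numbers, so that its effect appears only at larger amounts. Among the compounds with values here, the single step between them, a 3.3-fold higher number from compound 1 to compound 2 (0.51 log units; beyond the scatter), came with the change from a methoxycarbonyl group to a hydroxymethyl group on the same aromatic carbon.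

Compound 3 `CCOCc1c(C)coc1-c1ccc2c(CC)cccc2c1OC` differs from compound 2 by one change: ethyl in place of hydrogen on an oxygen on a saturated carbon. Within the data shown here, no measured step touches this oxygen, so the only guide is that compound 1, whose ester oxygen also carries a carbon rather than a hydrogen, gave the lower number in this assay. A modest move in that direction is therefore expected, yet with wide uncertainty. Compound 3 is estimated at 4.5 ug/mL in this assay, within a range from 1.5 ug/mL to 13 ug/mL, which would mean an expected step of a 1.6-fold lower number from compound 2 to compound 3 (0.20 log units; within the scatter).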

Compound 3, concentration for half-maximal effect: > 10 ug/mL
Compound 3 ended at the assay's limit; the forecaster's own chance of this, stated with the estimate: 5%; middle value at least 2.2-fold (0.34 log units) from the limit.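

In this assay compound 3 gives > 10 ug/mL, which is a limit of the assay and not a number. Ethoxymethyl in place of methoxycarbonyl leaves an at least 4.5-fold higher number from compound 1 to compound 3 (0.65 log units; beyond the scatter), so an ethyl on this oxygen does not bring back the lower number seen with the ester. The other step reads an at least 1.3-fold higher number from compound 2 to compound 3 (0.14 log units; that floor lies within the scatter), so it cannot be said whether ethyl on this oxygen truly raises the number over the free hydroxymethyl, and the real size of the step stays hidden at the limit: the limit of > 10 ug/mL in this assay, at which 1 of the 3 values shown sits.

Still open, as far as these compounds go, is how a methyl on this oxygen, or a carboxylic acid or an amide in place of methoxycarbonyl, would read in this assay. All three compounds vary only at this one aromatic carbon, so they say nothing about changes elsewhere on the shared core.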